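Swapping Fluoro for Methoxy on the Benzyl Arm

The compounds below may be only part of what the source reports. "The series", "measured", "known", "first", "only" and "open" are said of these compounds alone.

Of the compounds shown here, three built on one shared core have been tested in a functional assay on KM12 cells (Homo sapiens) for inhibition, read by sulforhodamine B assay, with a stated time of 48 h; a lower number here means a stronger inhibitor of growth, a higher number a weaker inhibitor of growth. Compound 1 `Nc1cc(N)c2nc(-c3ccccc3)c(NCc3ccc(Cl)c(Cl)c3)nc2c1` gives 3390 nM. Compound 2 `COc1ccc(CNc2nc3cc(N)cc(N)c3nc2-c2ccccc2)cc1OC` gives 13200 nM. Compound 3 `Nc1cc(N)c2nc(-c3ccccc3)c(NCc3ccc(F)cc3)nc2c1` gives 2820 nM, the lowest of the three numbers, although its gap to compound 1 lies within the scatter, so those two cannot be ranked; only compound 2 stands clearly apart, as the step of a 4.7-fold lower number from compound 2 to compound 3 (0.67 log units; beyond the scatter) shows.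

Compound 4 `COc1ccc(CNc2nc3cc(N)cc(N)c3nc2-c2ccccc2)cc1` has not yet been measured. It differs from compound 3 in one place: methoxy in place of fluoro on an aromatic carbon. For the measured compounds named here, two measured steps bear on this exchange. The step of a 3.9-fold higher number from compound 1 to compound 2 (0.59 log units; beyond the scatter) shows that replacing chlorines by methoxy groups raised the number, while the step of a 1.2-fold lower number from compound 1 to compound 3 (0.08 log units; within the scatter) shows that one halogen swapped for another barely moved it. The known methoxy case carried two methoxy groups, whereas compound 4 carries one, so a rise in number is expected in this assay, but a smaller one than for compound 2. Compound 4 is therefore expected to give about 6000 nM, within 2500 nM to 15000 nM. The expected step is a 2.1-fold higher number from compound 3 to compound 4 (0.33 log units; beyond the scatter), probably just beyond the scatter toward weaker inhibition.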

Compound 4, concentration for 50% growth inhibition: 13200 nM
Compound 4: the middle estimate sits 2.2-fold (0.34 log units) below what was measured; the range from low to high includes it.
By their numbers in this assay, from the lowest: compounds 3 and 1 (each within the scatter of the next); then compounds 2 and 4 (each within the scatter of the next).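

In this assay, methoxy in place of fluoro on the aromatic carbon para to a large group gives a 4.7-fold higher number from compound 3 to compound 4 (0.67 log units; beyond the scatter), while compound 2, with its added methoxy group, differs from compound 4 by nothing that can be told apart: no change at the digits printed from compound 2 to compound 4 (within the scatter). For the compounds shown here, the single methoxy group in compound 4 therefore goes with the same weaker growth inhibition as the pair in compound 2, and a second methoxy group adds no measurable loss here. The gap to the dichloro compound is correspondingly the same, at a 3.9-fold higher number from compound 1 to compound 4 (0.59 log units; beyond the scatter), but no measurement shown explains why one methoxy group at this position has this effect.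

As far as these compounds go, it remains open whether a hydroxyl, methyl or amino group on this same aromatic carbon would behave like fluoro or like methoxy, and how a plain benzyl arm with only hydrogen there would compare. Going by these compounds alone, also unsettled is whether the other methoxy group of compound 2, standing alone without the one it shares with compound 4, would raise the number as well.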